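Solubility at Neutral pH Across Three Measured Analogues and One Expected

The compounds below may be only part of what the source reports. "The series", "measured", "known", "first", "only" and "open" are said of these compounds alone.

Compound 1 `CNC(=O)c1cc(Oc2ccc3nc(Nc4cccc(C(F)(F)F)c4)ncc3c2)ccn1`, compound 2 `CNC(=O)c1cc(Oc2ccc3nc(Nc4cccc(C(C)C)c4)ncc3c2)ccn1` and compound 3 `CNC(=O)c1cc(Oc2ccc3nc(Nc4ccc(C(F)(F)F)cc4)ncc3c2)ccn1` share one core and differ only in the substituted phenyl group on a nitrogen on an aromatic ring. All three were tested in a physicochemical assay for solubility, at pH 7; on this read-out higher numbers stand for higher solubility and lower numbers for lower solubility. In this assay compound 1 gives < 1000 nM, which is a limit of the assay and not a number. In this assay compound 2 gives < 1000 nM, again a limit rather than a number. In this assay compound 3 gives < 1000 nM, also a limit.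

The change from compound 1 to compound 2 is isopropyl in place of trifluoromethyl on an aromatic carbon, and the step it made is a step that the two limits leave unreadable from compound 1 to compound 2. The cores of compound 1 and compound 3 differ as 4-(trifluoromethyl)phenyl in place of 3-(trifluoromethyl)phenyl on a nitrogen on an aromatic ring, with the step that the two limits leave unreadable from compound 1 to compound 3. Between compound 2 and compound 3 the step is a step that the two limits leave unreadable from compound 2 to compound 3. What ties these together is the limit of < 1000 nM in this assay, at which 3 of the 3 values shown sit.

Compound 4 `CNC(=O)c1cc(Oc2ccc3nc(Nc4ccc(C(C)C)cc4)ncc3c2)ccn1` has not yet been measured. It differs from compound 3 as isopropyl in place of trifluoromethyl on an aromatic carbon. For the measured compounds named here, this is the same kind of change as the one from compound 1 to compound 2, but the place differs: in compound 4 the isopropyl sits para to a large group, whereas in compound 2 it sits meta to a large group.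

For compound 4 the expected step is a step that the limit leaves unreadable from compound 3 to compound 4, which rests on compound 3 and its two neighbours all sitting at the limit of < 1000 nM in this assay, at which 3 of the 3 values shown sit. Compound 4 is therefore estimated at 500 nM, with a range from 100 nM to 1500 nM, and most likely reported only as a limit.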

Compound 4, solubility: < 1000 nM
Compound 4: a limit, no number; the forecaster's own chance of this, stated with the estimate: 85%; the middle value does not contradict the limit.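

In this assay compound 4 gives < 1000 nM as a limit of the assay and not a number. No step can be read between compound 4 and compound 1, compound 2 or compound 3, and all share one limit: the limit of < 1000 nM in this assay, at which 4 of the 4 values shown sit. The compounds shown leave open where any of the four truly stands in this assay and whether either change of group shifts that read-out at all.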